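Swapping the Piperazine Aryl Group for a Pyridinylmethyl

A few compounds are considered here, and "the series" means these few. Any claim that something is new, unique, unknown or untested is made for them only; others in the source may bear on it.

Measured compounds:
- compound 1, `Nc1ccccc1NC(=O)c1ccc(CSC(=S)N2CCN(Cc3ccccn3)CC2)cc1`: 61.4%
- compound 2, `Nc1ccccc1NC(=O)c1ccc(CSC(=S)N2CCN(c3ccc(F)cc3)CC2)cc1`: 64.5%
- compound 3, `Cc1ccc(N2CCN(C(=S)SCc3ccc(C(=O)Nc4ccccc4N)cc3)CC2)cc1`: 24%

In a functional assay on HeLa cells (Homo sapiens) for antiproliferative activity, read by CCK-8 assay, with a stated time of 72 h, tested at 8 uM (on this read-out higher numbers stand for a stronger effect at the one concentration tested and lower numbers for a weaker effect), compound 3 gives the lowest of the three numbers; it sits a number 37.4 percentage points lower from compound 1 to compound 3 (beyond the scatter) and a number 40.5 percentage points lower from compound 2 to compound 3 (beyond the scatter), both gaps beyond the scatter. Compound 1 and compound 2, in contrast, lie within the scatter of one another, as a number 3.1 percentage points higher from compound 1 to compound 2 (within the scatter) shows.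

Compound 4, `Nc1ccccc1NC(=O)c1ccc(CSC(=S)N2CCN(Cc3cccnc3)CC2)cc1`, is not yet measured. Its change from compound 3 is (pyridin-3-yl)methyl in place of 4-methylphenyl on an amine nitrogen in a ring. Going by the values given here, the closest precedent is the step in which the (pyridin-2-yl)methyl group of compound 1 was exchanged for the 4-methylphenyl group, which fell a number 37.4 percentage points lower from compound 1 to compound 3 (beyond the scatter). Among the compounds with values here, compound 4 reverses that kind of change, bringing back a pyridinylmethyl group, with the nitrogen now at the 3-position of the ring; no measured pair tells whether that shift of the nitrogen matters.

On this basis a large rise is expected, a number 34 percentage points higher from compound 3 to compound 4 (beyond the scatter), with compound 4 estimated at 58% (range 40% to 72%).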

Compound 4, a percentage reported as inhibition, at one concentration (the size of the read-out at that concentration, not a potency): 78%
The estimate for compound 4 lay 20 percentage points below the measured number; measured number outside the range, above it.
By their numbers in this assay, from the lowest: compound 3; then compounds 1 and 2 (each within the scatter of the next); then compound 4.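

In this assay, going by these compounds alone, moving the nitrogen within the pyridine ring, with nothing else changed, gives a number 16.6 percentage points higher from compound 1 to compound 4 (beyond the scatter), so the place of this atom matters at the chain carbon, which the earlier compounds could not reveal. The (pyridin-3-yl)methyl group also clears both aryl groups on the amine nitrogen in the ring: a number 13.5 percentage points higher from compound 2 to compound 4 (beyond the scatter) is a modest step and a number 54 percentage points higher from compound 3 to compound 4 (beyond the scatter) is a large one, although 4-methylphenyl and (pyridin-3-yl)methyl have the same count of heavy atoms. No measurement here explains why these groups differ.

As far as these compounds go, it remains open whether a (pyridin-4-yl)methyl group would extend this rise, and whether a plain benzyl group would keep it, which would show how much depends on the ring nitrogen at all. A reading at a single concentration also leaves the potency of compound 4 unknown.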